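Second chloro on the aryl ring: expectation for compound 4

The compounds below may be only part of what the source reports. "The series", "measured", "known", "first", "only" and "open" are said of these compounds alone.

Measured so far in a functional assay on HEp-2 cells (Homo sapiens) for cytotoxicity, read by MTT assay, with a stated time of 72 h, tested at 5 ug/mL; on this read-out higher numbers stand for more inhibition of growth at the one concentration tested and lower numbers for less inhibition of growth:
compound 1 `O=C1NC(=S)/C(=C/c2ccc(Cl)cc2)S1` gives 16.1%
compound 2 `O=C1NC(=S)/C(=C/c2cccc(Cl)c2)S1` gives 17.6%
compound 3 `O=C1NC(=S)/C(=C/c2cccc(F)c2)S1` gives 19.8%

On these numbers compound 2 stands second highest of three; the values of compound 1 and compound 3 lie on either side of it, each within the scatter, so the three are not separated. Going by the values given here, the only single-point step measured, a number 2.2 percentage points higher from compound 2 to compound 3 (within the scatter), fluoro in place of chloro on an aromatic carbon, also stays within the scatter.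

Compound 4 `O=C1NC(=S)/C(=C/c2ccc(Cl)c(Cl)c2)S1` differs from compound 2 by chloro in place of hydrogen on an aromatic carbon. Among the compounds with values here, no measured step adds a chloro to a ring that already carries one; the one step available exchanges a halogen for another and stays within the scatter. It bears only loosely on the present change, and nothing in the series points to a step beyond the scatter in this assay in either direction. The expected step is therefore a number 2.4 percentage points higher from compound 2 to compound 4 (within the scatter), within the scatter. Compound 4 is estimated at 20%, with a range from 8% to 34%.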

Compound 4, percent growth inhibition at one concentration: 11%
Compound 4: middle estimate off by 9 percentage points, on the high side, and the stated range covers the measured number.
By their numbers in this assay, from the lowest: compounds 4, 1, 2 and 3 (each within the scatter of the next).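

In this assay, going by these compounds alone, the steps of a number 6.6 percentage points lower from compound 2 to compound 4 (within the scatter) and a number 5.1 percentage points lower from compound 1 to compound 4 (within the scatter) are the first that put a group on the aromatic ring in place of hydrogen rather than exchange one halogen for another. Both steps stay within the scatter, so compound 4 is not separated from either compound carrying a single chloro. A chloro ortho to a chloro group and para to the group of 8 heavy atoms therefore gives no step beyond the scatter in this read-out.

From the compounds shown here alone, whether a methoxy group or an amine at the same place would behave like chloro remains open. So does whether a step beyond the scatter can be reached at this position at all, and no evidence bears on the reason for these steps.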